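Swapping Cyclopropylmethoxy for Cyclopropyl on Compound 1

This account rests on a few compounds, and the source may have more. Where it says the series, first, only, none or still open, it means among the compounds named here.

Measured so far in an ADME assay on liver (Homo sapiens) for metabolic stability, using microsomes; on this read-out lower numbers stand for a shorter-lived compound and higher numbers for a longer-lived compound:
compound 1 `CN1Cc2cc(ccc2S(=O)(=O)C2CC2)NC(=O)CCc2cc(ccc2OCC2CC2)[C@@H](Nc2ccc3c(N)ncc(F)c3c2)C1=O` gives 0.383 h
compound 2 `CN1CCc2cccc(c2)[C@@H](Nc2ccc3c(N)ncc(F)c3c2)C(=O)N(C)Cc2cc(ccc2S(=O)(=O)C2CC2)NC1=O` gives 0.0833 h
compound 3 `CN1Cc2cc(ccc2S(=O)(=O)C2CC2)NC(=O)N(CC2CC2)CCc2cccc(c2)C(Nc2ccc3c(N)ncc(F)c3c2)C1=O` gives 0.0833 h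

Compound 1 has the highest number of the three, and its gap to each of the other two lies beyond the usual scatter of repeated measurements. Compound 2 and compound 3 share the same number. Among the measured compounds shown here, no two measured compounds differ in one place only, so the data offer no direct guide to the effect of a single exchange.

The next compound, compound 4 `CN1Cc2cc(ccc2S(=O)(=O)C2CC2)NC(=O)CCc2cc(ccc2C2CC2)[C@@H](Nc2ccc3c(N)ncc(F)c3c2)C1=O`, has not yet been measured. It keeps the core of compound 1 but carries cyclopropyl in place of cyclopropylmethoxy on an aromatic carbon of that core.

In this assay a small step is expected, downward if anything, and none beyond the scatter. Compound 2 at 0.0833 h and compound 3 at 0.0833 h show that close relatives can sit well under compound 1, so the range stays wide on the lower side. The estimated step is a 1.3-fold lower number from compound 1 to compound 4 (0.11 log units; within the scatter) and it stays within the scatter. The estimate for compound 4 is 0.3 h, with an expected range from 0.1 h to 0.8 h and the measurement still to come.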

Compound 4, half-life: 0.433 h
Estimate against measurement, compound 4: 1.4-fold (0.16 log units) below; measured number inside the range.
By their numbers in this assay, from the lowest: compounds 2 and 3 (each within the scatter of the next); then compounds 1 and 4 (each within the scatter of the next).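

Among the compounds shown here, putting cyclopropyl in place of cyclopropylmethoxy on this aromatic carbon gives, in this assay, a 1.1-fold higher number from compound 1 to compound 4 (0.05 log units; within the scatter), and this is the first exchange that can be read on its own. At this position, the group can go from 5 heavy atoms to 3 and lose its one hydrogen-bond acceptor, the ether oxygen, with no change in half-life beyond the usual scatter, as long as the three-membered carbon ring stays in place. No measurement shown here offers a reason for this result.

As far as these compounds go, it remains open whether the half-life would hold with a different kind of group on this aromatic carbon, such as an amine, a carboxylic acid or a longer alkoxy chain, since the two groups compared here both carry a cyclopropyl ring. Compound 2 and compound 3 differ from compound 1 in more than one place, so they cannot show how much this position alone contributes to the gaps between those compounds.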